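Swapping fluoro for amino on a potent aroyl compound

The source may report more compounds than this note shows. Statements on the series, on what has been measured and on what is new or still open speak of the compounds shown alone.

compound 1 `COc1cc(C(=O)c2cn(-c3cccc(N)c3)cc2-c2ccc(N)cc2)cc(OC)c1OC` gives 51 nM
compound 2 `COc1cc(C(=O)c2cn(-c3ccc(F)cc3)cc2-c2ccc(N)cc2)cc(OC)c1OC` gives 35 nM

For the measured compounds named here, both values come from a functional assay on HT-29 cells (Homo sapiens) for cytotoxicity, read by MTT assay, with a stated time of 48 h (a higher number here means a weaker inhibitor, a lower number a stronger inhibitor), and are the only numbers available. Compound 2, at 35 nM, stands within the scatter of compound 1, so the two cannot be told apart on these data.

The next structure, compound 3 `COc1cc(C(=O)c2cn(-c3ccc(N)cc3)cc2-c2ccc(N)cc2)cc(OC)c1OC`, differs from compound 2 by amino in place of fluoro on an aromatic carbon, para to a large group (amino in place of fluoro on an aromatic carbon), the same difference reading 4-fluorophenyl to 4-aminophenyl.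

Going by the values given here, only one measured step bears on this change. It is a 1.5-fold lower number from compound 1 to compound 2 (0.16 log units; within the scatter), where 4-fluorophenyl replaces 3-aminophenyl on an aromatic nitrogen. That step also exchanges an amino-bearing ring for a fluoro-bearing one, but with the amino group elsewhere, so it is only an indirect guide. Its small size gives no reason to expect a large shift in this assay from the reverse kind of exchange.

The expected change, a 1.2-fold higher number from compound 2 to compound 3 (0.08 log units; within the scatter), is therefore no step beyond the scatter. For compound 3 the estimated value is 42 nM, with an expected range of 15 nM to 120 nM.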

Compound 3, half-maximal inhibitory concentration: 34 nM
Compound 3: middle estimate off by 1.2-fold (0.09 log units), on the high side, within the range that was stated.
By their numbers in this assay, from the lowest: compounds 3, 2 and 1 (each within the scatter of the next).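

In this assay the exchange of fluoro for amino on an aromatic carbon, para to a large group, can now be read directly as a 1.0-fold lower number from compound 2 to compound 3 (0.01 log units; within the scatter) and lies within the scatter. The earlier step could only approach this change indirectly, with the amino group elsewhere on the ring. The place of the amino group on the ring at the aromatic nitrogen can now also be read on its own, as a 1.5-fold lower number from compound 1 to compound 3 (0.18 log units; within the scatter) and again within the scatter, so neither the exchange of fluoro for amino nor the move from 3-aminophenyl to 4-aminophenyl separates these compounds, and no measurement at hand explains this result.

As far as these compounds go, all three compounds carry only amino or fluoro on this ring, so it remains open whether a hydroxyl, a carboxylic acid or a longer chain such as ethoxy at the same place would stay within the same range. Also open, from the compounds shown here alone, is what the second 4-aminophenyl group, shared by all three compounds, contributes in this assay and whether a chloro group there would change the number.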